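The source may report more compounds than this note shows. Statements on the series, on what has been measured and on what is new or still open speak of the compounds shown alone.

Three compounds share one core and differ only in the group attached to the carbonyl carbon. Compound 1 `O=C(/C=C/c1ccc2c(c1)B(O)OC2)c1cccs1` carries thiophen-2-yl there; in a functional assay on HCT-116 cells (Homo sapiens) for cytotoxicity, read by MTT assay, with a stated time of 48 h (on this read-out higher numbers stand for weaker inhibition and lower numbers for stronger inhibition), compound 1 gives 14200 nM. Compound 2 `Cn1cccc1C(=O)/C=C/c1ccc2c(c1)B(O)OC2` carries 1-methyl-1H-pyrrol-2-yl instead. In this assay compound 2 reaches only a limit of the assay, > 100000 nM. That change, an at least 7.0-fold higher number from compound 1 to compound 2 (0.84 log units; beyond the scatter), weakened inhibition, and its true size is known only as a floor since (the limit of > 100000 nM in this assay, at which 1 of the 2 values shown sits). Compound 3 `O=C(/C=C/c1ccc2c(c1)B(O)OC2)c1ccc(F)cc1` has not yet been measured in this assay. Its change from compound 2 is 4-fluorophenyl in place of 1-methyl-1H-pyrrol-2-yl on a carbonyl carbon. The single measured step at this position, from compound 1 to compound 2, shows that exchanging the ring here can move the read-out well beyond the scatter; whether a six-membered carbon ring behaves more like thiophen-2-yl or like the pyrrole is not shown. For compound 3 the expected step is an at least 5.0-fold lower number from compound 2 to compound 3 (0.69 log units; beyond the scatter). Compound 3 is therefore estimated at 20000 nM, with a range from 5000 nM to 100000 nM.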

Compound 3, half-maximal inhibitory concentration: 2800 nM
Estimate against measurement, compound 3: 7.1-fold (0.85 log units) above, outside the stated range (below it).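

In this assay, compound 3 with its 4-fluorophenyl group is the strongest of the three, with a 5.1-fold lower number from compound 1 to compound 3 (0.71 log units; beyond the scatter) and an at least 35-fold lower number from compound 2 to compound 3 (1.55 log units; beyond the scatter). The ring on the carbonyl carbon therefore need not be five-membered, and the three groups now rank, from stronger to weaker inhibition, as 4-fluorophenyl, thiophen-2-yl and 1-methyl-1H-pyrrol-2-yl. The step from the pyrrole is a floor rather than a full size, since compound 2 sits at a limit of the assay: the limit of > 100000 nM in this assay, at which 1 of the 3 values shown sits.

From the compounds shown here alone, whether the step to compound 3 comes from the six-membered carbon ring or from its fluorine stays open, and a plain phenyl group would help to separate the two. Also open, going by these compounds, is whether a ring is needed at this place at all, as against a longer chain such as butyl or an amine.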